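Dropping the benzyl from selenium in the phenylquinoline series

The source may hold more compounds than are shown below. What is called first, only, known or untested is meant among the compounds shown, and "the series" means these compounds.

Measured so far:
- compound 1, `C[Se]/C(=N\C(=O)c1cccs1)NC(=O)c1cccs1`: 12500 nM
- compound 2, `O=C(/N=C(/NC(=O)c1ccno1)[Se]Cc1ccccc1)c1ccno1`: > 100000 nM
- compound 3, `O=C(/N=C(/NC(=O)c1cc(-c2ccccc2)nc2ccccc12)[Se]Cc1ccccc1)c1cc(-c2ccccc2)nc2ccccc12`: 78900 nM

Three selenium-bearing bis-amides have been tested in a functional assay on HepG2 cells (Homo sapiens) for cytotoxicity, read by MTT assay, with a stated time of 72 h; a higher number here means that more compound is tolerated, a lower number that less compound is tolerated. Compound 1 gives 12500 nM. Compound 3 gives 78900 nM, the highest of the two actual numbers, and its gap to compound 1 lies beyond the usual scatter. Compound 2 reaches only the limit of the limit of > 100000 nM in this assay, at which 1 of the 3 values shown sits, so no number is known for it.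

The next compound, compound 4 (`C[Se]/C(=N\C(=O)c1cc(-c2ccccc2)nc2ccccc12)NC(=O)c1cc(-c2ccccc2)nc2ccccc12`), keeps the core of compound 3 and changes only the group on selenium: hydrogen in place of phenyl on a saturated chain carbon bound to a selenium atom. Compound 1 carries the same methyl on selenium, though with a different amide part, and it is the less tolerated of the two measured numbers. From that, the step from compound 3 to compound 4 in this assay is expected to run toward a lower number, of moderate size, and it is estimated as a 2.6-fold lower number from compound 3 to compound 4 (0.42 log units; beyond the scatter). Compound 4 is thus expected to give about 30000 nM, most likely between 10000 nM and 90000 nM.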

Compound 4, concentration lethal to 50% of the cells: 65400 nM
Compound 4: middle estimate off by 2.2-fold (0.34 log units), on the low side; the measured number falls inside the stated range.
By their numbers in this assay, from the lowest: compound 1; then compounds 4 and 3 (each within the scatter of the next). At a limit, above all of these: compound 2.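

Among these compounds, exchanging benzyl for methyl on selenium while the shared core stays fixed gives the first direct reading at this position: in this assay the pair shows a 1.2-fold lower number from compound 3 to compound 4 (0.08 log units; within the scatter) and so the two compounds cannot be told apart. On this core, the phenyl of the benzyl group can therefore be removed without a measurable shift in how much compound the cells tolerate. Among the compounds shown here, none of the earlier pairs offered a comparison of this kind, with only one place changed.

On these data alone, whether the same holds for a longer chain such as propyl, or for a group carrying an amine or a carboxylic acid on selenium, stays open, as does the same exchange with the amide parts of compound 1 or compound 2. Nothing measured here gives a reason for this result.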